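The source may report more compounds than this note shows. Statements on the series, on what has been measured and on what is new or still open speak of the compounds shown alone.

Measured in a functional assay on COLO 205 cells (Homo sapiens) for inhibition, read by sulforhodamine B assay; a higher number here means a weaker inhibitor of growth, a lower number a stronger inhibitor of growth:
- compound 1 `Oc1cccc2[nH]c(-c3ccc(-c4ccc(-c5ccccc5)cc4)cc3)nc12`: 1210 nM
- compound 2 `Oc1cccc2[nH]c(-c3ccc(-c4ccc(-c5ccc(C(F)(F)F)cc5)cc4)cc3)nc12`: 3410 nM
- compound 3 `Oc1cccc2[nH]c(-c3ccc(-c4ccc(-c5ccc(OC(F)(F)F)cc5)cc4)cc3)nc12`: 8320 nM

Compound 3, at 8320 nM, has the highest number of the three, making it the weakest growth inhibitor so far. Compound 4 `COc1ccc(-c2ccc(-c3ccc(-c4nc5c(O)cccc5[nH]4)cc3)cc2)cc1` differs from it by one change: methyl in place of trifluoromethyl on an oxygen on an aromatic ring. This places methyl in place of trifluoromethyl on an oxygen on an aromatic ring, so trifluoromethoxy becomes methoxy.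

Going by the values given here, no measured compound carries methoxy, so no step shows this change directly. The closest guide is trifluoromethoxy in place of hydrogen, which gave a 6.9-fold higher number from compound 1 to compound 3 (0.84 log units; beyond the scatter). Trifluoromethyl in place of hydrogen gave a 2.8-fold higher number from compound 1 to compound 2 (0.45 log units; beyond the scatter), and trifluoromethoxy in place of trifluoromethyl gave a 2.4-fold higher number from compound 2 to compound 3 (0.39 log units; beyond the scatter). All three steps are modest, and each fluorinated compound sits above the unsubstituted compound 1. A modest fall in the number is therefore expected on removing the fluorines, though a return fully to the level of compound 1 is not assumed. The expected change is a 3.0-fold lower number from compound 3 to compound 4 (0.47 log units; beyond the scatter). For compound 4 the estimated value is 2800 nM, with an expected range of 1100 nM to 7000 nM.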

Compound 4, concentration for 50% growth inhibition: 1630 nM
For compound 4 the middle estimate is 1.7-fold (0.23 log units) above the measured one; measured number inside the range.
By their numbers in this assay, from the lowest: compounds 1 and 4 (each within the scatter of the next); then compound 2; then compound 3.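

In this assay, replacing the three fluorines of trifluoromethoxy with hydrogens gives a 5.1-fold lower number from compound 3 to compound 4 (0.71 log units; beyond the scatter) and so shows that the penalty seen with compound 3 depends on those fluorines, not simply on having an oxygen-linked group at this position. Methoxy also compares well with trifluoromethyl, with a 2.1-fold lower number from compound 2 to compound 4 (0.32 log units; beyond the scatter) on this read-out. Methoxy in place of hydrogen gives a 1.3-fold higher number from compound 1 to compound 4 (0.13 log units; within the scatter) and is the first substitution here that does not clearly move the number away from that of compound 1, while trifluoromethyl and trifluoromethoxy both do; nothing measured here explains this difference.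

The compounds shown leave open how an amine, a carboxylic acid or a longer chain such as ethoxy would fare at this place. They also leave open whether a group with one or two fluorines would behave more like methoxy or more like trifluoromethoxy.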